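The source may hold more compounds than are shown below. What is called first, only, known or untested is meant among the compounds shown, and "the series" means these compounds.

Compound 1 `O=C1c2sc(C#Cc3ccccc3)nc2CN1C1CC1`: in an assay on HEK293 cells for positive allosteric modulation of metabotropic glutamate receptor 5 (Homo sapiens), read by FLIPR, with a stated time of 1 h (on this read-out higher numbers stand for an effect only at larger amounts of compound and lower numbers for an effect already at smaller amounts), compound 1 gives > 10000 nM, a limit of the assay rather than a number.
Compound 2 `CCN1CCc2nc(C#Cc3ccccc3)sc2C1`: compound 2 gives > 10000 nM, again a limit.
Compound 3 `O=C(C1CC(F)C1)N1CCc2nc(C#Cc3ccccc3)sc2C1`: compound 3 gives 85 nM.

Going by the values given here, compound 3 thus carries the only number in the set; the other two values sit at the limit of > 10000 nM in this assay, at which 2 of the 3 values shown sit. Among the compounds with values here, the single step measured in one place, an at least 110-fold lower number from compound 2 to compound 3 (2.07 log units; beyond the scatter), runs from a limit to a number when ethyl on the ring nitrogen is replaced by the (3-fluorocyclobutyl)carbonyl amide. Compound 4 `O=C(C1CCOCC1)N1CCc2nc(C#Cc3ccccc3)sc2C1` is not yet measured. It differs from compound 3 by oxan-4-yl in place of 3-fluorocyclobutyl on a carbonyl carbon, the amide carbonyl being kept. Within the data shown here, no measured step bears directly on this ring swap; the one step known concerns gaining the amide, not the ring on it. A step within the scatter, in no firm direction, is expected: a 1.8-fold higher number from compound 3 to compound 4 (0.25 log units; within the scatter). For compound 4 the estimate in this assay is 150 nM, within 40 nM to 600 nM.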

Compound 4, half-maximal effective concentration: 290 nM
For compound 4 the middle estimate is 1.9-fold (0.29 log units) below the measured one; the range from low to high includes it.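

The group on the carbonyl carbon, not only the presence of the amide, shifts the result: in this assay there is a 3.4-fold higher number from compound 3 to compound 4 (0.53 log units; beyond the scatter). The gain over ethyl survives this swap, with an at least 34-fold lower number from compound 2 to compound 4 (1.53 log units; beyond the scatter), so it does not rest on 3-fluorocyclobutyl alone. Compound 2 gives a limit, not a number: the limit of > 10000 nM in this assay, at which 2 of the 4 values shown sit.

Compound 3 and compound 4 differ in both ring size and hetero atom, and these two changes cannot be separated here. Open too, as far as these compounds go, is how an unsubstituted cyclobutyl or a piperidin-4-yl amine on the carbonyl carbon would read.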